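Compound 4 after a limit at compound 3

A few compounds are considered here, and "the series" means these few. Any claim that something is new, unique, unknown or untested is made for them only; others in the source may bear on it.

In an ADME assay on microsomes from liver (Rattus norvegicus) for metabolic stability, read by LC-MS, using NADPH, at 37 degrees C (a higher number here means that the compound lasts longer, a lower number that the compound disappears faster), compound 3 (`Cc1ccccc1-c1nc(CN2CCC(C(=O)NCCCN3[C@H](C)CCC[C@@H]3C)CC2)c(C)o1`) gives > 0.5 h as a limit of the assay, not a number. Compound 1 (`Cc1ccccc1-c1nc(CN2CCC(C(=O)NCCCN3CCC(C)CC3)CC2)c(C)o1`) gives > 0.5 h as a limit too. Within the data shown here, the one measured step, a step that the two limits leave unreadable from compound 1 to compound 3, therefore offers no size to carry over. Compound 2 (`Cc1oc(-c2ccc(F)cc2)nc1CN1CCC(C(=O)NCCCN2C[C@H](C)C[C@H](C)C2)CC1`), which also carries a 3,5-dimethylpiperidin-1-yl group, gives 0.468 h as an actual number. Compound 4 (`Cc1ccccc1-c1nc(CN2CCC(C(=O)NCCCCN3C[C@H](C)C[C@H](C)C3)CC2)c(C)o1`) has (3,5-dimethylpiperidin-1-yl)methyl in place of 2,6-dimethylpiperidin-1-yl on a saturated chain carbon, three bonds along the chain from an amide-type nitrogen. Among the measured compounds shown here, with compound 2 at 0.468 h as the only number to lean on, no step beyond the scatter is expected in this assay, and the expected change reads an at least 1.1-fold lower number from compound 3 to compound 4 (0.04 log units; that floor lies within the scatter) without a firm direction. Compound 4 is estimated at 0.45 h with an expected range of 0.22 h to 0.9 h.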

Compound 4, half-life: 0.2 h
Estimate against measurement, compound 4: 2.3-fold (0.35 log units) above; the measured number lies below the stated range.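

In this assay, this place on the saturated chain carbon now gives a readable change: (3,5-dimethylpiperidin-1-yl)methyl brings an at least 2.5-fold lower number from compound 3 to compound 4 (0.39 log units; beyond the scatter) and also an at least 2.5-fold lower number from compound 1 to compound 4 (0.39 log units; beyond the scatter). Both sizes are only floors, and the earlier step between the two limits cannot be read: the limit of > 0.5 h in this assay, at which 2 of the 4 values shown sit.

The change enters the longer chain and the 3,5-dimethylpiperidin-1-yl ring together, so the compounds shown leave open which of the two carries the fall. They also leave open how a morpholine at this place would read.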